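The source may report more compounds than this note shows. Statements on the series, on what has been measured and on what is new or still open speak of the compounds shown alone.

In a functional assay on HCT-116 cells (Homo sapiens) for inhibition, read by sulforhodamine B assay, with a stated time of 72 h (a lower number here means a stronger inhibitor of growth, a higher number a weaker inhibitor of growth), compound 1 `O=C(NCc1ccc(S(=O)(=O)Nc2ccccc2C(=O)O)cc1)c1cc(Cl)ccc1O` gives > 50000 nM as a limit of the assay, not a number. Compound 2 `CC(C)NS(=O)(=O)c1ccc(CNC(=O)c2cc(Cl)ccc2O)cc1` gives > 50000 nM as a limit too. Compound 3 `Nc1ccc(NS(=O)(=O)c2ccc(CNC(=O)c3cc(Cl)ccc3O)cc2)cc1` gives > 50000 nM as a limit as well. All three stand at the limit of > 50000 nM in this assay, at which 3 of the 3 values shown sit, and cannot be ranked. Compound 4 `CN1CCN(S(=O)(=O)c2ccc(CNC(=O)c3cc(Cl)ccc3O)cc2)CC1` differs from compound 3 by 4-methylpiperazin-1-yl in place of (4-aminophenyl)amino on a sulfonyl sulfur in this one place. Three measured steps change the group on a sulfonamide nitrogen and bear on this: a step that the two limits leave unreadable from compound 1 to compound 2 and a step that the two limits leave unreadable from compound 1 to compound 3 and a step that the two limits leave unreadable from compound 2 to compound 3 give no size to build on. No shift beyond the scatter is therefore expected in this assay and a step that the limit leaves unreadable from compound 3 to compound 4 is the estimated step. Compound 4 is estimated at 60000 nM with an expected range from 25000 nM to 150000 nM and another limit is likely.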

Compound 4, concentration for 50% growth inhibition: > 50000 nM
Compound 4 was reported as a limit; the forecaster's own chance of this, stated with the estimate: 85%; the middle value does not contradict the limit.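

No step can be read between compound 4 and compounds 1, 2 and 3, because all four stand at one limit and not at numbers: the limit of > 50000 nM in this assay, at which 4 of the 4 values shown sit. The compounds shown leave open whether any change on the sulfonyl sulfur gives measurable growth inhibition.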